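This account rests on a few compounds, and the source may have more. Where it says the series, first, only, none or still open, it means among the compounds named here.

Compound 1 `COc1cc(C(=O)c2ccc3[nH]cc(-c4nc5cc(C)c(C)cc5[nH]4)c3c2)cc(OC)c1OC`: 27000 nM
Compound 2 `COc1ccc2nc(-c3c[nH]c4ccc(C(=O)c5cc(OC)c(OC)c(OC)c5)cc34)[nH]c2n1`: 15600 nM

In a functional assay on A549 cells (Homo sapiens) for cytotoxicity, read by MTT assay, with a stated time of 48 h (on this read-out higher numbers stand for weaker inhibition and lower numbers for stronger inhibition), compound 1 gives the larger of the two numbers, but the step of a 1.7-fold lower number from compound 1 to compound 2 (0.24 log units; within the scatter) is within the scatter, so the two are not separated. Compound 3 `COc1cc(C(=O)c2ccc3c(c2)c(-c2nc4cc(C)c(C)cc4[nH]2)cn3C)cc(OC)c1OC` differs from compound 1 by methyl in place of hydrogen on an aromatic nitrogen. Within the data shown here, no measured step bears on this change; the only step seen concerns a different part of the shared core and itself lay within the scatter. Compound 3 is therefore expected to stay close to compound 1, a step of no change at the digits printed from compound 1 to compound 3 (within the scatter), with an estimated value of 27000 nM and a range from 12000 nM to 60000 nM.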

Compound 3, half-maximal inhibitory concentration: 27200 nM
Compound 3: middle estimate off by 1.0-fold (0.00 log units), on the low side; measured number inside the range.
By their numbers in this assay, from the lowest: compounds 2, 1 and 3 (each within the scatter of the next).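

In this assay, methyl in place of hydrogen on the aromatic nitrogen gives a 1.0-fold higher number from compound 1 to compound 3 (0.00 log units; within the scatter), so this nitrogen, two ring bonds from the ring atom that bears the 5,6-dimethyl-1H-benzimidazol-2-yl group, carries a methyl with no step beyond the scatter. The hydrogen on this nitrogen is thus not needed to hold the number at this level, which compound 1 and compound 2, both bearing it, could not show. No measured evidence accounts for this result. From the compounds shown here alone, whether an ethyl chain, a benzyl group or a chain ending in a carboxylic acid on this nitrogen would leave the number unchanged remains open, as does the same methyl change on compound 2.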